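The source may hold more compounds than are shown below. What is called first, only, known or untested is meant among the compounds shown, and "the series" means these compounds.

In a physicochemical assay for solubility, at pH 6.8 (a higher number here means a more soluble compound, a lower number a less soluble compound), compound 1 `CN(C)Cc1ccc(-c2cnc(N)c(C(=O)NC[C@@](C)(O)C(F)(F)F)n2)cc1` gives 510000 nM and compound 2 `CN(C)Cc1ccc(-c2cnc(N)c(C(=O)NC3CCCCC3)n2)cc1` gives 190000 nM. Compound 1 holds the higher of these two numbers, and the measured change is a 2.7-fold lower number from compound 1 to compound 2 (0.43 log units; beyond the scatter). Compound 3 `CC(O)CNC(=O)c1nc(-c2ccc(CN(C)C)cc2)cnc1N` reads > 1000000 nM, which is a limit of the assay and not a number.

Compound 4 `C[C@@](O)(CNC(=O)c1nc(-c2ccc(CN3CCCC3)cc2)cnc1N)C(F)(F)F` keeps the rest of compound 1 and differs at one place: pyrrolidin-1-yl in place of dimethylamino on a saturated chain carbon bound to an aromatic carbon. It carries pyrrolidin-1-yl in place of dimethylamino on a saturated chain carbon bound to an aromatic carbon. For the measured compounds named here, no measured step changes that place. All three change the group on the amide-type nitrogen, so a 2.7-fold lower number from compound 1 to compound 2 (0.43 log units; beyond the scatter), an at least 1.9-fold higher number from compound 1 to compound 3 (0.29 log units; that floor lies within the scatter) and an at least 5.2-fold higher number from compound 2 to compound 3 (0.72 log units; beyond the scatter) bear on it only loosely, as a guide to how far this assay has moved within this small set. No step beyond the scatter is therefore expected, in either direction. The expected step is a 1.2-fold lower number from compound 1 to compound 4 (0.08 log units; within the scatter). For compound 4 the estimated value is 420000 nM, with an expected range from 170000 nM to 950000 nM.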

Compound 4, solubility: > 1000000 nM
Compound 4: a limit, no number; the forecaster's own chance of this, stated with the estimate: 10%; middle value at least 2.3-fold (0.37 log units) from the limit.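

Among the compounds shown, only compound 4 changes the (dimethylamino)methyl group rather than the group on the amide-type nitrogen. In this assay compound 4 reads > 1000000 nM, which is a limit of the assay and not a number. The step for pyrrolidin-1-yl in place of dimethylamino is an at least 1.9-fold higher number from compound 1 to compound 4 (0.29 log units; that floor lies within the scatter), so at this place the five-membered non-aromatic ring brings no drop in the reading, though the true size of the step stays unknown because the reading stops here: the limit of > 1000000 nM in this assay, at which 2 of the 4 values shown sit.

As far as these compounds go, whether pyrrolidin-1-yl shifts the reading when the amide-type nitrogen carries cyclohexyl, as in compound 2, remains open. So does how a morpholine, a piperidine or a diethylamino group would read at this same place on the shared core.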